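The source may report more compounds than this note shows. Statements on the series, on what has been measured and on what is new or still open speak of the compounds shown alone.

Compound 1 `CCCCOC(=O)NS(=O)(=O)c1sc(CC(C)C)cc1-c1ccc(Cc2ncco2)cc1` gives 3.9 nM in an assay on membranes from uterus for displacement of a labelled ligand from Angiotensin type II receptor (Sus scrofa), with a stated time of 1.5 h; a higher number here means a weaker inhibitor, a lower number a stronger inhibitor. Compound 2 `CCCCOC(=O)NS(=O)(=O)c1sc(CC(C)C)cc1-c1ccc(CN2C(=O)N(C)C(C)(C)C2=O)cc1` gives 3.6 nM in this assay. Compound 3 `CCCCOC(=O)NS(=O)(=O)c1sc(CC(C)C)cc1-c1ccc(C(=O)c2cccs2)cc1` gives 18.8 nM in this assay.

Compound 3 has the highest number of the three: the step of a 4.8-fold higher number from compound 1 to compound 3 (0.68 log units; beyond the scatter) and the step of a 5.2-fold higher number from compound 2 to compound 3 (0.72 log units; beyond the scatter) both lie beyond the scatter, so compound 3 is the weakest inhibitor of the measured set. Compound 4 `CCCCOC(=O)NS(=O)(=O)c1sc(CC(C)C)cc1-c1ccc(C(=O)c2nccs2)cc1` differs from compound 3 only by 1,3-thiazol-2-yl in place of thiophen-2-yl on a carbonyl carbon. Within the data shown here, no measured step exchanges one five-membered aromatic ring for another on the carbonyl carbon; the nearest comparison, a 1.1-fold lower number from compound 1 to compound 2 (0.03 log units; within the scatter), swaps a ring on a saturated chain carbon and stays within the scatter. Since the carbonyl link to the shared core is kept, a step within the scatter is expected: a 1.3-fold lower number from compound 3 to compound 4 (0.10 log units; within the scatter). Compound 4 is therefore estimated at 15 nM, in the range 6 nM to 40 nM.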

Compound 4, inhibition constant: 18.6 nM
Beside the measured number, compound 4's estimate is 1.2-fold (0.09 log units) below it, and the stated range covers the measured number.
By their numbers in this assay, from the lowest: compounds 2 and 1 (each within the scatter of the next); then compounds 4 and 3 (each within the scatter of the next).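

Exchanging thiophen-2-yl for 1,3-thiazol-2-yl on the carbonyl carbon leaves the number in this assay unchanged (a 1.0-fold lower number from compound 3 to compound 4 (0.00 log units; within the scatter)), so at this position the second ring hetero atom makes no visible difference. The gaps to the two compounds without this carbonyl link also remain beyond the scatter (a 4.8-fold higher number from compound 1 to compound 4 (0.68 log units; beyond the scatter); a 5.2-fold higher number from compound 2 to compound 4 (0.71 log units; beyond the scatter)). Both five-membered aromatic rings tested on this carbonyl carbon therefore give the same result.

As far as these compounds go, what an amine or a longer chain would do on this carbonyl carbon remains open. No available data explain why this exchange leaves the number unchanged.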